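Swapping the amide aryl group on a weak chromone inhibitor

The source may report more compounds than this note shows. Statements on the series, on what has been measured and on what is new or still open speak of the compounds shown alone.

Compound 1, drawn as `COc1ccc2c(=O)c(/C=C/C(=O)Nc3cc(C)ccc3C)coc2c1`, is a chromone-type amide that was tested in a functional assay on HeLa cells (Homo sapiens) for inhibition, read by MTT assay, with a stated time of 48 h; a higher number here means a weaker inhibitor, a lower number a stronger inhibitor. In this assay, among the measured compounds shown here, compound 1 gives 58400 nM, which is the only full number available in this small set and marks it as a weak inhibitor. A second compound, compound 2 with the structure `COc1ccc(NC(=O)/C=C/c2coc3cc(O)ccc3c2=O)cc1`, reached only > 100000 nM in this assay, and that figure is a limit of the assay rather than a number. For the measured compounds named here, with no pair of measured compounds differing in a single place, no measured step can be quoted.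

The unmeasured compound 3, drawn as `CCOc1ccc(NC(=O)/C=C/c2coc3cc(OC)ccc3c2=O)cc1`, differs from compound 1 in one place: 4-ethoxyphenyl in place of 2,5-dimethylphenyl on an amide-type nitrogen. In this assay, going by the values given here, the step from compound 1 to compound 3 is expected to be small, with a 1.2-fold higher number from compound 1 to compound 3 (0.08 log units; within the scatter) lying within the usual scatter, since no measured step shows how this part of the molecule matters. On that basis compound 3 is expected to give about 70000 nM in this assay, plausibly anywhere from 25000 nM to 150000 nM, with a real chance that only a limit is reported.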

Compound 3, half-maximal inhibitory concentration: > 100000 nM
Compound 3 was reported as a limit; the forecaster's own chance of this, stated with the estimate: 40%; middle value at least 1.4-fold (0.15 log units) away from the limit.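

Among the compounds shown here, replacing 2,5-dimethylphenyl with 4-ethoxyphenyl on the amide-type nitrogen gives the first measured step at this position in this assay (an at least 1.7-fold higher number from compound 1 to compound 3 (0.23 log units; that floor lies within the scatter)). Going by these compounds, the entry for compound 3 is a limit of the assay and not a number, so the true size of this step is unknown: it could be no larger than ordinary scatter, or it could be much larger. What the change does show is that this swap does not bring a full number into view, and readings in this series are hard to compare because many of them stop at the same upper end of the assay: the limit of > 100000 nM in this assay, at which 2 of the 3 values shown sit.

The compounds shown leave open whether any group on the amide-type nitrogen matters in this assay, since one measured number and a limit cannot separate a real loss from scatter. On these data alone, it also remains unknown whether a phenyl ring carrying an amine or a carboxylic acid, or a longer chain such as butoxy in place of the ethoxy group, would give a full number well below that upper end.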